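Lengthening the chain of compound 2

The source may report more compounds than this note shows. Statements on the series, on what has been measured and on what is new or still open speak of the compounds shown alone.

In a functional assay on HT-29 cells (Homo sapiens) for inhibition, read by sulforhodamine B assay, with a stated time of 72 h (on this read-out lower numbers stand for stronger inhibition and higher numbers for weaker inhibition), compound 1 (`COc1cc2c(Nc3ccc(F)c(Cl)c3)ncnc2cc1OCCCCCCn1ccnc1[N+](=O)[O-]`) gives 5630 nM and compound 2 (`COc1cc2c(Nc3ccc(OCc4cccc(F)c4)c(Cl)c3)ncnc2cc1OCCCn1ccnc1[N+](=O)[O-]`) gives 3790 nM. Within the data shown here, these two values lie within the usual scatter of each other, so compound 2 stands level with compound 1 on the only numbers available. Compound 3 (`COc1cc2c(Nc3ccc(OCc4cccc(F)c4)c(Cl)c3)ncnc2cc1OCCCCCCn1ccnc1[N+](=O)[O-]`) has not yet been measured. It differs from compound 2 by 3-(2-nitro-1H-imidazol-1-yl)propyl in place of 2-nitro-1H-imidazol-1-yl on a saturated chain carbon, three bonds along the chain from an oxygen on an aromatic ring, with 3-(2-nitro-1H-imidazol-1-yl)propyl in place of 2-nitro-1H-imidazol-1-yl on a saturated chain carbon, three bonds along the chain from an oxygen on an aromatic ring. Among the measured compounds shown here, no measured pair isolates this change. Compound 3 shares its chain with compound 1, which gives 5630 nM, so no step beyond the scatter is expected in this assay. The estimate amounts to a 1.1-fold lower number from compound 2 to compound 3 (0.03 log units; within the scatter). Compound 3 is expected at 3500 nM, within an estimated range of 1400 nM to 9000 nM.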

Compound 3, half-maximal inhibitory concentration: > 50000 nM
Compound 3: only a limit was reported (the forecaster's own chance of this, stated with the estimate: 5%); at least 14-fold (1.15 log units) between middle value and limit.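

In this assay compound 3 gives > 50000 nM, which is a limit of the assay and not a number. The longer chain brings an at least 13-fold higher number from compound 2 to compound 3 (1.12 log units; beyond the scatter), and (3-fluorobenzyl)oxy in place of fluoro brings an at least 8.8-fold higher number from compound 1 to compound 3 (0.94 log units; beyond the scatter), both beyond the scatter. The earlier compounds shown here stood level and each carried only one of these two features, so only now is it seen that the changes do not simply pass unnoticed when combined: at this saturated chain carbon, the effect of the longer chain depends on the group at the other end of the molecule.

From the compounds shown here alone, how large the two steps really are stays open, since only a bound is available: the limit of > 50000 nM in this assay, at which 1 of the 3 values shown sits. Also open are whether a chain of intermediate length keeps the activity of compound 2, and whether an amine in place of the 2-nitro-1H-imidazol-1-yl group would change the picture on the longer chain.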